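This account rests on a few compounds, and the source may have more. Where it says the series, first, only, none or still open, it means among the compounds named here.

Measured in a functional assay on HeLa cells (Homo sapiens) for antiproliferative activity, read by MTT assay, with a stated time of 24 h; on this read-out lower numbers stand for stronger inhibition and higher numbers for weaker inhibition:
- compound 1 `O=[N+]([O-])c1cccc(CSc2nnc(-c3ccc4c(c3)OCCO4)n2-c2ccccc2)c1` gives 45200 nM
- compound 2 `Clc1ccccc1CSc1nnc(-c2ccc3c(c2)OCCO3)n1-c1ccccc1` gives 29000 nM
- compound 3 `Clc1cccc(CSc2nnc(-c3ccc4c(c3)OCCO4)n2-c2ccccc2)c1` gives 15000 nM

Compound 3 stands level with compound 2, with a 1.9-fold lower number from compound 2 to compound 3 (0.29 log units; within the scatter), and clear of compound 1, with a 3.0-fold lower number from compound 1 to compound 3 (0.48 log units; beyond the scatter). Compound 4 `Cc1ccc(CSc2nnc(-c3ccc4c(c3)OCCO4)n2-c2ccccc2)cc1` has 4-methylphenyl in place of 3-chlorophenyl on a saturated chain carbon bound to a sulfur. The nearest evidence is the same kind of exchange in a 1.6-fold lower number from compound 1 to compound 2 (0.19 log units; within the scatter) and in the two steps above. Among the measured compounds shown here, these steps are small, and none of the compounds measured so far carries 4-methylphenyl. The expected move is slight and towards a higher number, within the scatter, with a 1.5-fold higher number from compound 3 to compound 4 (0.17 log units; within the scatter). For compound 4 the estimated value is 22000 nM, with an expected range from 9000 nM to 55000 nM.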

Compound 4, half-maximal inhibitory concentration: 49700 nM
Compound 4: the middle estimate sits 2.3-fold (0.35 log units) below what was measured; the measured number falls inside the stated range.
By their numbers in this assay, from the lowest: compounds 3, 2, 1 and 4 (each within the scatter of the next, the first and the last beyond it).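

At this position, on a saturated chain carbon bound to a sulfur, 4-methylphenyl in this assay lies beyond the scatter of 3-chlorophenyl (a 3.3-fold higher number from compound 3 to compound 4 (0.52 log units; beyond the scatter)) but within that of 2-chlorophenyl (a 1.7-fold higher number from compound 2 to compound 4 (0.23 log units; within the scatter)) and 3-nitrophenyl (a 1.1-fold higher number from compound 1 to compound 4 (0.04 log units; within the scatter)). Compound 3 is thus set apart from compounds 1 and 4, while compound 2 stays within the scatter of all three. No available evidence accounts for these steps.

The step to compound 4 exchanges both the ring substituent and where it stands, leaving 3-methylphenyl and 4-chlorophenyl as the open comparisons. Also open, from the compounds shown here alone, is how an amine, a carboxylic acid or a longer chain would read here.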